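This account rests on a few compounds, and the source may have more. Where it says the series, first, only, none or still open, it means among the compounds named here.

Two compounds carry numbers in an assay on lysate for inhibition of 6-phosphofructo-2-kinase/fructose-2,6-bisphosphatase 3 (Homo sapiens), with stated times of 0.5 min and 45 min; a higher number here means a weaker inhibitor, a lower number a stronger inhibitor. Compound 1 `Cn1ccc2ccc(-c3cc(Nc4ccccc4S(N)(=O)=O)cc4nccnc34)cc21` gives 37600 nM in this assay, and compound 2 `CN1CCCC(NS(=O)(=O)c2ccccc2Nc2cc(-c3ccc4ccn(C)c4c3)c3nccnc3c2)C1` gives 9780 nM, the lower of the two values. For the measured compounds named here, that difference is the single step so far: a 3.8-fold lower number from compound 1 to compound 2 (0.58 log units; beyond the scatter). Compound 3 `CN(Cc1cncnc1)S(=O)(=O)c1ccccc1Nc1cc(-c2ccc3ccn(C)c3c2)c2nccnc2c1` follows from compound 2 by methyl((pyrimidin-5-yl)methyl)amino in place of (1-methylpiperidin-3-yl)amino on a sulfonyl sulfur. Going by the values given here, no measured pair changes the substituent on the sulfonamide nitrogen from one carbon group to another; the one step available only replaces hydrogen there, and it bears on the new change only loosely. With nothing more to lean on, the expectation for compound 3 is a number close to that of compound 2, that is a 1.2-fold higher number from compound 2 to compound 3 (0.09 log units; within the scatter), a step expected to fall within the scatter. Compound 3 is therefore estimated at 12000 nM in this assay, with a range from 4000 nM to 40000 nM.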

Compound 3, half-maximal inhibitory concentration: > 100000 nM
Compound 3 was reported as a limit; the forecaster's own chance of this, stated with the estimate: 10%; at least 8.3-fold (0.92 log units) between middle value and limit.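

Compound 3 is reported in this assay only as a limit of the assay: the limit of > 100000 nM in this assay, at which 1 of the 3 values shown sits.

Even so, the change on the sulfonyl sulfur gives an at least 10-fold higher number from compound 2 to compound 3 (1.00 log units; beyond the scatter), which shows that the group at this position can move the number upward as well as downward. The comparison with the unsubstituted sulfonamide gives an at least 2.6-fold higher number from compound 1 to compound 3 (0.42 log units; beyond the scatter), so replacing the hydrogen on the sulfonamide nitrogen does not by itself lower the number: compound 2 follows that direction, and compound 3 goes against it.

The change swaps the ring and adds a methyl on the sulfonamide nitrogen in one step, so the compounds shown cannot separate the two. A (pyrimidin-5-yl)methylamino group without that methyl, or an open-chain amine such as 2-(dimethylamino)ethylamino, would bear on which part carries the difference.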